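A few compounds are considered here, and "the series" means these few. Any claim that something is new, unique, unknown or untested is made for them only; others in the source may bear on it.

Measured compounds:
- compound 1 `C=CCc1cc(O)c(O)c(CN2CCC(C)CC2)c1` gives 41.7%
- compound 2 `C=CCc1ccc(OCc2cn(-c3cc(OC)c(OC)c(OC)c3)nn2)c(O)c1` gives 37.3%
- compound 3 `C=CCc1ccc(OCc2cn(-c3ccc(OC)cc3)nn2)c(O)c1` gives 38.8%

These three values come from a functional assay on MCF7 cells (Homo sapiens) for inhibition, read by MTT assay, with a stated time of 72 h, tested at 30 uM (a lower number here means less inhibition of growth, a higher number more inhibition of growth at the concentration tested), and sit close together. Compound 3 stands in the same band as the other two, and compound 2 and compound 1 both lie within the usual scatter of it, so no order can be read among them.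

Compound 4 `C=CCc1ccc(OCc2cn(-c3ccc(Br)cc3)nn2)c(O)c1` has not yet been measured. It differs from compound 3 in one place only. The change is bromo in place of methoxy on an aromatic carbon and in words it is bromo in place of methoxy on an aromatic carbon, para to a large group, or 4-methoxyphenyl to 4-bromophenyl.

Among the measured compounds shown here, no two measured compounds differ in a single place, so the data hold no direct measure of such a swap. Compound 2 at 37.3% and compound 3 at 38.8% lie within the scatter of each other, and on this slim ground no step beyond the scatter is expected in this assay for this change, only a slight rise if any. The estimated step of a number 3.2 percentage points higher from compound 3 to compound 4 (within the scatter) is small and stays within the scatter. For compound 4 the estimated value is 42% with an expected range from 30% to 55% for a single measurement.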

Compound 4, percent growth inhibition at one concentration: 19.4%
The estimate for compound 4 lay 22.6 percentage points above the measured number; the whole stated range lies above it.
By their numbers in this assay, from the lowest: compound 4; then compounds 2, 3 and 1 (each within the scatter of the next).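

In this assay, among the compounds shown here, bromo in place of methoxy on an aromatic carbon, para to a large group, gives the first step between two compounds that differ in one place only: a number 19.4 percentage points lower from compound 3 to compound 4 (beyond the scatter). The earlier values sat together and could not show whether this place mattered, whereas this pair shows that growth inhibition at the concentration tested is sensitive to the group held there, with 4-methoxyphenyl keeping more of it than 4-bromophenyl in this one comparison. Nothing available bears on the reason for this loss, so the step stands as an observation without an explanation.

Going by these compounds, what remains open is whether the loss belongs to bromo itself or follows from the absence of methoxy, since a single swap cannot separate the two. A chloro, a methyl or an amino group at the same place would show whether the value stays with that of compound 3 or falls with that of compound 4, and only such further groups could turn this single step into a trend.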